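Pyrrolidine amides: aryl-for-pyridyl swap at the far ring

This account rests on a few compounds, and the source may have more. Where it says the series, first, only, none or still open, it means among the compounds named here.

Three compounds in the series carry measured numbers in an assay on HEK293 cells for inhibition of N-acylethanolamine-hydrolyzing acid amidase (Rattus norvegicus), read by LC-MS, with a stated time of 30 min; on this read-out lower numbers stand for stronger inhibition and higher numbers for weaker inhibition. Compound 1 `O=C(CCCCCCc1ccc(F)cc1)N1CCCC1` gives 8000 nM. Compound 2 `O=C(CCCCCCc1ccccc1Cl)N1CCCC1` returns only a limit, > 100000 nM, which is the limit of the assay rather than a number, as recorded in the limit of > 100000 nM in this assay, at which 1 of the 3 values shown sits. Compound 3 `Cc1ccc(-c2ccc(CCC(=O)N3CCCC3)cc2)cc1` gives 33200 nM, the highest of the two numbers reported; compound 1 sits lower, and the gap between them lies beyond the usual scatter of this assay. Among the measured compounds shown here, no pair among the measured compounds differs in one place only, so no single measured step is available.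

Compound 4 `O=C(CCc1ccc(-c2cccnc2)cc1)N1CCCC1` has not yet been run in this assay. Relative to compound 3 the change is pyridin-3-yl in place of 4-methylphenyl on an aromatic carbon, in words pyridin-3-yl in place of 4-methylphenyl on an aromatic carbon. For the measured compounds named here, nothing among the measured compounds isolates this swap, so no measured step supports a direction. The working expectation is a step from compound 3 to compound 4 of no clear size beyond the scatter, written as a 1.1-fold lower number from compound 3 to compound 4 (0.04 log units; within the scatter). On that basis compound 4 is estimated at 30000 nM in this assay, with a plausible range from 8000 nM to 100000 nM; the upper end allows for a limit being reported instead of a number.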

Compound 4, half-maximal inhibitory concentration: > 100000 nM
Compound 4 ended at the assay's limit; the forecaster's own chance of this, stated with the estimate: 25%; at least 3.3-fold (0.52 log units) between middle value and limit.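

In this assay, the series now has its first step between compounds that differ in one place: an at least 3.0-fold higher number from compound 3 to compound 4 (0.47 log units; beyond the scatter). Among the compounds shown here, at this position, on an aromatic carbon para to a group of 9 heavy atoms, replacing 4-methylphenyl with pyridin-3-yl exchanges a ring of carbon only for a ring with 1 hetero atom and 1 hydrogen-bond acceptor, and it moves the read-out towards weaker inhibition, a direction the earlier compounds could not give. Compound 4 gives > 100000 nM, which is a limit of the assay and not a number, so the step fixes the direction and only a minimum size: the limit of > 100000 nM in this assay, at which 2 of the 4 values shown sit.

The swap changes the ring atom and removes the methyl group together, so the compounds shown cannot separate the two changes, and a plain phenyl group at this position would be needed to do so. They also leave open whether pyridin-4-yl, or a 4-methylpyridin-3-yl ring that keeps the methyl group, would return a number rather than a limit.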